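Moving the Chlorine on the Terminal Phenyl Urea

This account rests on a few compounds, and the source may have more. Where it says the series, first, only, none or still open, it means among the compounds named here.

Compound 3 `CCN(CC)CCNc1nc(-c2ccc(NC(=O)Nc3ccc(Cl)cc3)cc2)nc2c(Cl)c(Cl)sc12` gives 750 nM in a functional assay on MDA-MB-231 cells (Homo sapiens) for cytotoxicity, read by MTT assay, with a stated time of 72 h (a lower number here means a stronger inhibitor, a higher number a weaker inhibitor), the lowest number among the three measured compounds, though its gaps to compound 2 `CCN(CC)CCNc1nc(-c2ccc(NC(=O)Nc3ccc(F)cc3)cc2)nc2c(Cl)c(Cl)sc12` at 1130 nM and to compound 1 `CN(C)CCNc1nc(-c2ccc(NC(=O)Nc3ccccc3Cl)cc2)nc2c(Cl)c(Cl)sc12` at 1350 nM both lie within the scatter. Compound 4 `CCN(CC)CCNc1nc(-c2ccc(NC(=O)Nc3ccccc3Cl)cc2)nc2c(Cl)c(Cl)sc12` differs from compound 3 by 2-chlorophenyl in place of 4-chlorophenyl on an amide-type nitrogen. For the measured compounds named here, no measured step matches this change directly. Going by the values given here, the only step measured on this aryl group, a 1.5-fold lower number from compound 2 to compound 3 (0.18 log units; within the scatter), concerns a different exchange of halogen. Compound 1, which also carries a 2-chlorophenyl on the urea but a shorter amine chain, shows a number close to that of compound 3. Compound 4 is therefore expected to stay near compound 3, with at most a small rise, a 1.5-fold higher number from compound 3 to compound 4 (0.17 log units; within the scatter). Compound 4 is estimated at 1100 nM, within a range from 500 nM to 2500 nM.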

Compound 4, half-maximal inhibitory concentration: 1410 nM
Compound 4: middle estimate off by 1.3-fold (0.11 log units), on the low side; the measured number falls inside the stated range.
By their numbers in this assay, from the lowest: compounds 3, 2, 1 and 4 (each within the scatter of the next).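

Moving the chlorine from 4-chlorophenyl to 2-chlorophenyl on the amide-type nitrogen gives a 1.9-fold higher number from compound 3 to compound 4 (0.27 log units; within the scatter) in this assay, the first direct reading of this change, while 2-chlorophenyl in place of 4-fluorophenyl gives a 1.2-fold higher number from compound 2 to compound 4 (0.10 log units; within the scatter). With 2-chlorophenyl held fixed, diethylamino in place of dimethylamino gives a 1.0-fold higher number from compound 1 to compound 4 (0.02 log units; within the scatter). Neither the chlorine's place on the ring nor this amine exchange moves the number beyond the scatter. No measurement here explains these steps. As far as these compounds go, whether a methoxyphenyl or pyridyl group on this nitrogen would do so remains open.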